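The source may report more compounds than this note shows. Statements on the series, on what has been measured and on what is new or still open speak of the compounds shown alone.

Measured so far in an in vitro ADME assay on a cell-free system (plasma) for pharmacokinetics; a higher number here means that the compound lasts longer, a lower number that the compound disappears faster:
compound 1 `C=CCN(CCCC(=O)O)C(=O)/C(C)=C/c1ccc(C(=O)Oc2ccc(C(=N)N)cc2)cc1` gives > 1 h, a limit of the assay.
compound 2 `CCOC(=O)CCCN(C(=O)/C(C)=C/c1ccc(C(=O)Oc2ccc(C(=N)N)cc2)cc1)C(C(=O)OCC)C(=O)OCC` gives < 0.0167 h, a limit of the assay.
compound 3 `CCOC(=O)CN(C(=O)/C(C)=C/c1ccc(C(=O)Oc2ccc(C(=N)N)cc2)cc1)C1CCCC1` gives < 0.0834 h, a limit of the assay.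

For the measured compounds named here, compound 3 therefore stands at a limit and not at a number, (the limit of < 0.0834 h in this assay, at which 1 of the 3 values shown sits); the other two values shown are likewise limits, so no step between measured compounds can be sized. Compound 4 `CCOC(=O)CN(Cc1ccccc1)C(=O)/C(C)=C/c1ccc(C(=O)Oc2ccc(C(=N)N)cc2)cc1` differs from compound 3 by benzyl in place of cyclopentyl on an amide-type nitrogen, the ethyl ester chain on that nitrogen being kept. Going by the values given here, with no measured step to lean on, the expected step that the limit leaves unreadable from compound 3 to compound 4 is none beyond the scatter, in either direction. Compound 4 is estimated at 0.05 h, between 0.01 h and 0.3 h, with a fair chance that again only a limit is returned.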

Compound 4, half-life: < 0.0167 h
Compound 4 gave a limit, no number; the forecaster's own chance of this, stated with the estimate: 65%; middle value at least 2.9-fold (0.47 log units) away from the limit.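

For the compounds shown here, compound 3 and compound 4 each return only a limit in this assay, so no step between them can be read. On these data alone, whether benzyl in place of cyclopentyl on an amide-type nitrogen shifts the half-life remains open.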